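Benzyl for 1-methylbutyl at the alkylated ring nitrogen

A few compounds are considered here, and "the series" means these few. Any claim that something is new, unique, unknown or untested is made for them only; others in the source may bear on it.

Compound 1, `CCCCCNc1oc2c(C)ncc(CO)c2c1Nc1ccccn1`, gives 5810 nM in a functional assay on HEK293 cells for agonist activity at Toll-like receptor 8 (Homo sapiens), read by reporter gene assay; a lower number here means that less compound is needed, a higher number that more compound is needed for the effect.
Compound 2, `CCCCCNc1oc2c(C)ncc(CO)c2c1Nc1cccc([N+](=O)[O-])c1`, gives 850 nM in this assay.
Compound 3, `CCCC(C)Nc1oc2c(C)ncc(CO)c2c1Nc1ccccn1`, gives 9010 nM in this assay.

Compound 3 carries the highest number of the three. Its nearest neighbour is compound 1, and the step of a 1.6-fold higher number from compound 1 to compound 3 (0.19 log units; within the scatter) sits within the scatter, so the two cannot be ordered. Among the measured compounds shown here, compound 2 stands furthest from compound 3, and the step of a 6.8-fold lower number from compound 1 to compound 2 (0.83 log units; beyond the scatter), made on the other nitrogen, is the only change in this set that moves the number beyond the scatter.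

Compound 4, `Cc1ncc(CO)c2c(Nc3ccccn3)c(NCc3ccccc3)oc12`, has not been measured in this assay. It differs from compound 3 by benzyl in place of 1-methylbutyl on a nitrogen on an aromatic ring. For the measured compounds named here, the one measured step at this position, a 1.6-fold higher number from compound 1 to compound 3 (0.19 log units; within the scatter), exchanged one saturated chain for another and stayed within the scatter. Going by the values given here, no measured step brings an aromatic ring onto this nitrogen, so the step of a 6.8-fold lower number from compound 1 to compound 2 (0.83 log units; beyond the scatter) on the other nitrogen gives no direct guide here. The expectation for compound 4 is therefore a step of a 1.3-fold lower number from compound 3 to compound 4 (0.11 log units; within the scatter), no clearer than the scatter, with the range kept wide. Compound 4 is estimated at 7000 nM, between 2500 nM and 20000 nM.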

Compound 4, half-maximal effective concentration: 4910 nM
For compound 4 the middle estimate is 1.4-fold (0.15 log units) above the measured one; measured number inside the range.
By their numbers in this assay, from the lowest: compound 2; then compounds 4, 1 and 3 (each within the scatter of the next).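

Exchanging 1-methylbutyl for benzyl on a nitrogen on an aromatic ring gives a 1.8-fold lower number from compound 3 to compound 4 (0.26 log units; within the scatter) in this assay, so a six-membered aromatic ring can enter this group without a step beyond the scatter. Read against the straight chain, phenyl in place of butyl gives a 1.2-fold lower number from compound 1 to compound 4 (0.07 log units; within the scatter), and pentyl, 1-methylbutyl and benzyl therefore cannot be ordered at this nitrogen from these numbers. Three quite different groups now read alike here, while the only step beyond the scatter among the compounds shown remains a 6.8-fold lower number from compound 1 to compound 2 (0.83 log units; beyond the scatter), made on the other nitrogen.

No supporting data bear on why these groups read alike. Open, from the compounds shown here alone, is whether a longer chain, a cyclohexylmethyl group or a benzyl carrying a methoxy group on its ring would move the number beyond the scatter at this nitrogen, and whether 3-nitrophenyl on the other nitrogen would give the same step with benzyl in place as it does with pentyl.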